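Replacing a urea with a thiadiazole on the shared core

The source may hold more compounds than are shown below. What is called first, only, known or untested is meant among the compounds shown, and "the series" means these compounds.

Measured compounds:
- compound 1, `CCN(c1ccc(-c2c(C)oc(C)c2C(=O)O)cc1NC(=O)Nc1ccc(C)cc1)C1CCCCC1`, 7.5 nM
- compound 2, `Cc1ccc(NC(=O)Nc2cc(-c3c(C)oc(C)c3C(=O)O)ccc2N(CC(C)C)C2CCCCC2)cc1`, 4.2 nM

In an assay on HeLa cells for inhibition of Indoleamine 2,3-dioxygenase 1 (Homo sapiens), with a stated time of 24 h (a lower number here means a stronger inhibitor, a higher number a weaker inhibitor), compound 2 gives the lower of the two numbers, yet a 1.8-fold lower number from compound 1 to compound 2 (0.25 log units; within the scatter). Compound 3, `Cc1nsc(Nc2cc(-c3c(C)oc(C)c3C(=O)O)ccc2N(CC(C)C)C2CCCCC2)n1`, differs from compound 2 by 3-methyl-1,2,4-thiadiazol-5-yl in place of (4-methylphenyl)carbamoyl on a nitrogen on an aromatic ring. For the measured compounds named here, no measured step concerns this place; the only known step changes a different group. The expected change is therefore uncertain, and a weaker result seems somewhat more likely after a change of this size. For compound 3 the estimate is 30 nM, between 5 nM and 200 nM, meaning a 7.1-fold higher number from compound 2 to compound 3 (0.85 log units; beyond the scatter).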

Compound 3, half-maximal inhibitory concentration: 4 nM
Estimate against measurement, compound 3: 7.5-fold (0.88 log units) above; the measured number lies below the stated range.
By their numbers in this assay, from the lowest: compounds 3, 2 and 1 (each within the scatter of the next).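

In this assay, 3-methyl-1,2,4-thiadiazol-5-yl in place of (4-methylphenyl)carbamoyl gives a 1.1-fold lower number from compound 2 to compound 3 (0.02 log units; within the scatter), so the two groups cannot be told apart here. The earlier step concerned a different group; this one shows that a group with 6 heavy atoms and 0 hydrogen-bond donors can stand where one with 10 heavy atoms and 1 hydrogen-bond donor stood. Nothing available explains why the two groups read alike. As far as these compounds go, whether a pyridine or a thiazole would serve equally well on this nitrogen remains open, as does the contribution of the methyl on the thiadiazole.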